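The compounds below may be only part of what the source reports. "The series", "measured", "known", "first", "only" and "open" are said of these compounds alone.

Of the compounds shown here, three have so far been tested in an assay on isolated protein for inhibition of Rho-associated protein kinase 1 (Homo sapiens), tested at 30 uM; on this read-out lower numbers stand for less inhibition and higher numbers for more inhibition at the one concentration tested (going by the name of the read-out). Compound 1 `Clc1ncnc2ncn(Cc3ccccc3)c12` gives 6% in this assay. Compound 2 `Fc1ccc(Cn2cnc3ncnc(Cl)c32)cc1` differs from compound 1 in a single place: fluoro in place of hydrogen on an aromatic carbon. In this assay compound 2 gives 7%, and the step of a number 1 percentage points higher from compound 1 to compound 2 (within the scatter) is too small to be read as a real change. Compound 3 `Cn1cnc2c(-c3ccccc3)ncnc21` is built on a different core; how the two cores differ is not broken down here. In this assay compound 3 gives 8%. All three numbers lie within the usual scatter of one another, so on this evidence the inhibition in this assay is level across the three compounds and no number can be called higher or lower than another.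

Compound 4 `Cn1cnc2c(-c3ccc(F)cc3)ncnc21` has not yet been measured in this assay. It differs from compound 3 in one place: fluoro in place of hydrogen on an aromatic carbon. This is the same change that separates compound 1 from compound 2, made at a place described in identical words in both pairs, and it is seen in these two pairs only. The expectation for the step of a number 1 percentage points higher from compound 3 to compound 4 (within the scatter) rests on what this change did once before, namely a number 1 percentage points higher from compound 1 to compound 2 (within the scatter). On that basis compound 4 is expected to give about 9% in this assay. The estimate for compound 4 is expected to lie between 0% and 19%, with a real shift beyond the scatter unlikely from the evidence in hand.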

Compound 4, a percentage reported as inhibition, at one concentration (the size of the read-out at that concentration, not a potency): 10%
The estimate for compound 4 lay 1 percentage points below the measured number; low and high end bracket the measured number.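

In this assay, placing fluoro in place of hydrogen on an aromatic carbon, para to a large group, gives a number 2 percentage points higher from compound 3 to compound 4 (within the scatter). Set beside the earlier case, the same change on a different core gives a step of much the same size, so on these two pairs it carries across without any difference that can be told apart from assay noise: the same change on two cores in this assay, a number 1 percentage points higher (within the scatter) from compound 1 to compound 2 and a number 2 percentage points higher (within the scatter) from compound 3 to compound 4, 1 percentage points apart, within the scatter of two such steps

This agreement is only an agreement between two steps that are each too small to count as real, so it shows that the change had no detectable effect on either core, not that a real effect of fluoro travels from one core to another. Two pairs are also too few to say how the change would behave on any further core, least of all on one that gives clearly stronger inhibition.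

The compounds shown leave open whether any group other than fluoro on the six-membered aromatic ring, such as an amine, a methoxy group or a carboxylic acid, would shift the inhibition beyond the scatter. They also leave open what a longer chain in place of the methyl group on the core of compound 3 would do.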